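A few compounds are considered here, and "the series" means these few. Any claim that something is new, unique, unknown or untested is made for them only; others in the source may bear on it.

Measured so far:
- Compound 1, `CC(C)c1cccc(-c2cc3cc(C(=N)N)ccc3[nH]2)c1O`, gives 4400 nM in an assay on isolated protein for inhibition of Suppressor of tumorigenicity 14 protein (Homo sapiens), read by fluorescence; a lower number here means a stronger inhibitor, a higher number a weaker inhibitor.
- Compound 2, `N=C(N)c1ccc2[nH]c(-c3cccc(N4CCCCC4)n3)cc2c1`, gives 1500 nM in this assay.

Of these two numbers, compound 2 has the lower one, and the gap to compound 1 lies beyond the usual scatter of repeated measurements, so compound 2 is the stronger inhibitor of the pair. Compound 3, `N=C(N)c1ccc2[nH]c(-c3cccc(C4(O)CCCCC4)n3)cc2c1`, has not yet been measured. It differs from compound 2 in one place: 1-hydroxycyclohexyl in place of piperidin-1-yl on an aromatic carbon. Both groups are six-membered non-aromatic rings of similar size, but one hydrogen-bond donor is gained. Going by the values given here, no step between measured compounds of this kind is available, so the expectation rests on the size of the change alone. Compound 3 is expected to stay close to compound 2, with a step of a 1.3-fold higher number from compound 2 to compound 3 (0.12 log units; within the scatter) that is unlikely to go beyond the scatter. Compound 3 is therefore estimated at 2000 nM, within a range from 600 nM to 6000 nM.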

Compound 3, inhibition constant in the Suppressor of tumorigenicity 14 protein assay: 2100 nM
Compound 3: middle estimate off by 1.1-fold (0.02 log units), on the low side; the measured number falls inside the stated range.
By their numbers in the Suppressor of tumorigenicity 14 protein assay, from the lowest: compounds 2 and 3 (each within the scatter of the next); then compound 1.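

In the Suppressor of tumorigenicity 14 protein assay, where compound 2 gives 1500 nM and compound 3 gives 2100 nM, 1-hydroxycyclohexyl in place of piperidin-1-yl on the aromatic carbon next to the ring nitrogen gives a 1.4-fold higher number from compound 2 to compound 3 (0.15 log units; within the scatter), so the two compounds cannot be told apart as inhibitors. This carbon therefore tolerates at least this exchange of one six-membered non-aromatic ring for another, even with a hydrogen-bond donor gained. In a physicochemical assay for solubility, read by spectrophotometry and HPLC, at pH 7.4 (on this read-out lower numbers stand for lower solubility and higher numbers for higher solubility), where compound 2 gives 135000 nM and compound 3 gives 148000 nM, the same exchange likewise gives a 1.1-fold higher number from compound 2 to compound 3 (0.04 log units; within the scatter). Nothing available explains why these pairs of numbers stay so close.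

A plain cyclohexyl group at this carbon would help separate the contribution of the hydroxyl from that of the ring itself. Going by these compounds, since both groups here are six-membered rings, it also remains open how a much smaller or differently built group, such as a primary amine or a carboxylic acid, would fare.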